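The source may report more compounds than this note shows. Statements on the series, on what has been measured and on what is new or still open speak of the compounds shown alone.

Compound 1 `CCOc1cccc(-c2ccc(CN(C(=O)C3CCCCC3)c3cccc(/C=C/C(=O)OC)c3)cc2)c1` and compound 2 `COC(=O)/C=C/c1cccc(N(Cc2ccc(-c3ccc(C)cc3)cc2)C(=O)C(C)C)c1` both carry a methyl ester on the propenyl chain, and in an assay on isolated protein with Bile acid receptor (Homo sapiens) as the target (on this read-out higher numbers stand for an effect only at larger amounts of compound and lower numbers for an effect already at smaller amounts), compound 1 gives 147 nM while compound 2 gives 118 nM; these two values lie within the scatter of each other. Compound 3 `CC(C)(C)OC(=O)/C=C/c1ccc(CN(C(=O)C2CCCCC2)c2cccc(/C=C/C(N)=O)c2)cc1` stands apart: in this assay compound 3 gives only the limit of > 1000 nM, so no number is known for it (the limit of > 1000 nM in this assay, at which 1 of the 3 values shown sits). Compound 4 `CCOC/C=C/c1cccc(N(Cc2ccc(/C=C/C(=O)OC(C)(C)C)cc2)C(=O)C2CCCCC2)c1` differs from compound 3 in one place, (ethoxymethyl in place of carbamoyl on a double-bonded chain carbon bound to a double-bonded chain carbon), that is, ethoxymethyl in place of carbamoyl on a double-bonded chain carbon bound to a double-bonded chain carbon. Because compound 3 sits at the limit of > 1000 nM, the size of the step from compound 3 to compound 4 cannot be fixed in either direction; the step is expected to bring compound 4 back toward a measurable value, as an at least 1.6-fold lower number from compound 3 to compound 4 (0.22 log units; that floor lies within the scatter). The value of compound 4 in this assay is therefore estimated at 600 nM, with a range from 150 nM to 2500 nM.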

Compound 4, half-maximal effective concentration: 220 nM
Estimate against measurement, compound 4: 2.7-fold (0.44 log units) above, and the stated range covers the measured number.
By their numbers in this assay, from the lowest: compounds 2, 1 and 4 (each within the scatter of the next). At a limit, above all of these: compound 3.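

Going by these compounds alone, with compounds 3 and 4, a single change can be read for the first time: in this assay, ethoxymethyl in place of carbamoyl on a double-bonded chain carbon bound to a double-bonded chain carbon gives an at least 4.5-fold lower number from compound 3 to compound 4 (0.65 log units; beyond the scatter). This shows that the group at this place bears on the read-out, and that a measured value is reached with an entering group that has no hydrogen-bond donor, whereas the leaving carbamoyl has one. The true size of the step stays open because compound 3 stands at a limit, which is not a number: the limit of > 1000 nM in this assay, at which 1 of the 4 values shown sits.

The compounds shown leave open whether the ether oxygen or the chain length matters, as a plain propyl chain would help to tell. They also leave open how a carboxylic acid, an amine or a nitrile would read at this place.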